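Cyclopropyl to propyl on the ring: cytotoxicity expectation

The source may hold more compounds than are shown below. What is called first, only, known or untested is meant among the compounds shown, and "the series" means these compounds.

Compound 1 `CSc1ccc(CN[C@@H]2C[C@H]3C[C@@H]([C@H]2C)C3(C)C)s1`, compound 2 `C[C@H]1[C@H](NCc2cc(C3CC3)cs2)C[C@H]2C[C@@H]1C2(C)C` and compound 3 `CCc1ccsc1CN[C@@H]1C[C@H]2C[C@@H]([C@H]1C)C2(C)C` share one core and differ only in the substituent on the five-membered aromatic ring with one sulfur. In an ADME assay on MDCK cells (Canis lupus familiaris) for cytotoxicity, read by microscopy, with a stated time of 48 h (a lower number here means that less compound is tolerated, a higher number that more compound is tolerated), compound 1 gives 25000 nM. Compound 2 gives 25000 nM in this assay, and compound 3 gives 25000 nM. Compound 2 thus stands level with compounds 1 and 3 at the digits shown, within the scatter. Compound 4 `CCCc1csc(CN[C@@H]2C[C@H]3C[C@@H]([C@H]2C)C3(C)C)c1` awaits measurement in this assay; it differs from compound 2 by propyl in place of cyclopropyl on an aromatic carbon. Given that compound 1 at 25000 nM and compound 3 at 25000 nM sit level with compound 2 despite different ring substituents, no step beyond the scatter is expected for no change at the digits printed from compound 2 to compound 4 (within the scatter). Compound 4 is expected to give 25000 nM in this assay, within 12500 nM to 50000 nM.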

Compound 4, minimum cytotoxic concentration: 12500 nM
For compound 4 the middle estimate is 2.0-fold (0.30 log units) above the measured one, within the range that was stated.
By their numbers in this assay, from the lowest: compounds 4, 1, 2 and 3 (each within the scatter of the next).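

In this assay, among these compounds, the change from cyclopropyl to propyl on an aromatic carbon, two ring bonds from the ring sulfur, gives a 2.0-fold lower number from compound 2 to compound 4 (0.30 log units; within the scatter) in the first comparison of the series that differs in one place. At this position, a three-membered ring of carbon only and an open chain of the same heavy-atom count are therefore not told apart by this read-out. No measurement shown offers an explanation for this result. From the compounds shown here alone, whether an amine, a carboxylic acid or a longer chain at this position would give a step beyond the scatter remains open.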